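This account rests on a few compounds, and the source may have more. Where it says the series, first, only, none or still open, it means among the compounds named here.

Measured compounds:
- compound 1 `Cc1cc(C(=O)Nc2cccc(F)c2)nn1Cc1cc(Cl)ccc1OCc1ccccc1`: 200 nM
- compound 2 `Cc1cc(NC(=O)C2CCOC2)nn1Cc1cc(Cl)ccc1OCc1ccccc1`: 39.8 nM
- compound 3 `Cc1cc(NC(=O)c2ccccc2)nn1Cc1cc(Cl)ccc1OCc1ccccc1`: 15.9 nM

In an assay on CHO-K1 cells for displacement of a labelled ligand from prostaglandin E2 receptor EP1 subtype (Homo sapiens) (on this read-out higher numbers stand for weaker inhibition and lower numbers for stronger inhibition), compound 3 gives the lowest number of the three, and both of its neighbours lie beyond the scatter: a 2.5-fold lower number from compound 2 to compound 3 (0.40 log units; beyond the scatter) and a 13-fold lower number from compound 1 to compound 3 (1.10 log units; beyond the scatter). The step to compound 4 `Cc1cc(NC(=O)OCc2ccccc2)nn1Cc1cc(Cl)ccc1OCc1ccccc1` is benzyloxy in place of phenyl on a carbonyl carbon. For the measured compounds named here, the only steps that bear on it are those that also change the group on the carbonyl carbon: a 2.5-fold lower number from compound 2 to compound 3 (0.40 log units; beyond the scatter) and a 5.0-fold lower number from compound 1 to compound 2 (0.70 log units; beyond the scatter). Going by the values given here, each shows that this position matters at a modest scale, with the plain phenyl giving the lowest number so far. A benzyloxy group has not been measured, so a modest rise in the number is expected, a 2.5-fold higher number from compound 3 to compound 4 (0.40 log units; beyond the scatter), and compound 4 is estimated at 40 nM, with a range from 10 nM to 160 nM.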

Compound 4, half-maximal inhibitory concentration: 79.4 nM
The estimate for compound 4 lay 2.0-fold (0.30 log units) below the measured number; the measured number falls inside the stated range.
By their numbers in this assay, from the lowest: compound 3; then compounds 2 and 4 (each within the scatter of the next); then compound 1.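

Extending the group on the carbonyl carbon from phenyl to benzyloxy weakens binding in this assay (a 5.0-fold higher number from compound 3 to compound 4 (0.70 log units; beyond the scatter)), so this position does not simply reward a larger group that keeps the aromatic ring. Benzyloxy and oxolan-3-yl cannot be told apart (a 2.0-fold higher number from compound 2 to compound 4 (0.30 log units; within the scatter)), while (benzyloxycarbonyl)amino still outperforms (3-fluorophenyl)carbamoyl (a 2.5-fold lower number from compound 1 to compound 4 (0.40 log units; beyond the scatter)). No evidence here explains these differences.

Going by these compounds, it remains open how benzylamino or a phenylethyl chain would compare with benzyloxy on this carbonyl carbon. Also open, on these data alone, is whether a fluorine on the phenyl of compound 3 would change its number.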